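The source may hold more compounds than are shown below. What is called first, only, known or untested is meant among the compounds shown, and "the series" means these compounds.

Compound 1, `CCCCOC(=O)Nc1cc2nc(C3CCCCC3)[nH]c2cc1N(CC)CC` — in an ADME assay on Vero cells (Chlorocebus sabaeus) for cytotoxicity, read by resazurin assay, with a stated time of 3 days (on this read-out lower numbers stand for stronger inhibition and higher numbers for weaker inhibition), compound 1 gives > 100 ug/mL, which is a limit of the assay and not a number.
Compound 2, `C=Cc1cccc(C(=O)Nc2cc3nc(C4CCCCC4)[nH]c3cc2N(CC)CC)c1` — in this assay compound 2 gives > 100 ug/mL, again a limit of the assay.
Compound 3, `CCCCNC(=O)Nc1cc2nc(C3CCCCC3)[nH]c2cc1N(CC)CC` — in this assay compound 3 gives > 100 ug/mL, also a limit of the assay.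

Compound 3 therefore stands at the ceiling of what this assay can report, and it shares that position with the two other compounds, since all three values sit at the limit of > 100 ug/mL in this assay, at which 3 of the 3 values shown sit. Compound 4, `CCOCCOC(=O)Nc1cc2nc(C3CCCCC3)[nH]c2cc1N(CC)CC`, differs from compound 3 in one place: 2-ethoxyethoxy in place of butylamino on a carbonyl carbon.

Two measured steps lead into compound 3, a step that the two limits leave unreadable from compound 1 to compound 3 and a step that the two limits leave unreadable from compound 2 to compound 3, but both run between limits, so their size cannot be read and they give no direction for the change at hand. With no readable step among the measured compounds, the expectation for the step that the limit leaves unreadable from compound 3 to compound 4 is no movement beyond the scatter. Compound 4 is thus estimated at 150 ug/mL, within a range from 60 ug/mL to 500 ug/mL, most likely reported as a limit once more.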

Compound 4, half-maximal inhibitory concentration: > 100 ug/mL
Compound 4 ended at the assay's limit (the forecaster's own chance of this, stated with the estimate: 85%); the middle value is on the limit's open side.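

Compound 4 joins compounds 1, 2 and 3 at a limit of the assay, so none of the steps from those three compounds to compound 4 can be read: the limit of > 100 ug/mL in this assay, at which 4 of the 4 values shown sit.

The compounds shown leave open whether these four groups differ at all in this assay and at what concentration, if any, each compound would reach half-maximal inhibition.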